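A few compounds are considered here, and "the series" means these few. Any claim that something is new, unique, unknown or untested is made for them only; others in the source may bear on it.

Compound 1 `O=C(CN1CCN(c2ccc(Cl)cc2)CC1)N1CCN(c2nnc(-c3ccccc3)c(-c3ccccc3)n2)CC1` gives 113000 nM in an ADME assay on NIH3T3 cells (Mus musculus) for cytotoxicity, read by MTT assay, with a stated time of 24 h; a higher number here means a weaker inhibitor, a lower number a stronger inhibitor. Compound 2 `O=C(CN1CCN(c2ccc([N+](=O)[O-])cc2)CC1)N1CCN(c2nnc(-c3ccccc3)c(-c3ccccc3)n2)CC1` reaches only a limit of the assay, > 886000 nM, in this assay. The change from compound 1 to compound 2 is nitro in place of chloro on an aromatic carbon, and it made a step of an at least 7.8-fold higher number from compound 1 to compound 2 (0.89 log units; beyond the scatter). Compound 3 `COc1ccc(-c2nnc(N3CCN(C(=O)CN4CCN(c5ccc(Cl)cc5)CC4)CC3)nc2-c2ccc(OC)cc2)cc1` likewise returns only a limit in this assay, > 814000 nM. How the core of compound 3 differs from the core of compound 1 is not broken down here. Compound 4 `COc1ccc(-c2nnc(N3CCN(C(=O)CN4CCN(c5ccc([N+](=O)[O-])cc5)CC4)CC3)nc2-c2ccc(OC)cc2)cc1` carries the same change as compound 1 to compound 2, (nitro in place of chloro on an aromatic carbon). Since compound 3 already sits at the limit of > 814000 nM in this assay, at which 1 of the 3 values shown sits, the step from compound 3 to compound 4 is expected to read a step that the limit leaves unreadable from compound 3 to compound 4, with little room shown below it. Compound 4 is therefore estimated at 1000000 nM in this assay, most likely reported as a limit again.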

Compound 4, half-maximal inhibitory concentration: > 801000 nM
Compound 4 gave a limit, no number (the forecaster's own chance of this, stated with the estimate: 85%); the middle value lies beyond the limit too.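

For the compounds shown here, compound 3 and compound 4 both return only limits in this assay, so no step between them can be read. Going by these compounds, whether nitro in place of chloro changes the number on the core of compound 3 remains open.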